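Compound 3 and the Swap from Methyl to Cyano

A few compounds are considered here, and "the series" means these few. Any claim that something is new, unique, unknown or untested is made for them only; others in the source may bear on it.

Measured in a functional assay on HT-29 cells (Homo sapiens) for inhibition, read by CCK-8 assay, with a stated time of 24 h; on this read-out higher numbers stand for weaker inhibition and lower numbers for stronger inhibition:
Compound 1 (`Cc1cccc(-n2cc(-c3ccc(/C=C4\C(=O)Nc5ccc(F)cc54)cc3)nn2)c1`): 7320 nM
Compound 2 (`N#Cc1ccccc1-n1cc(-c2ccc(C=C3C(=O)Nc4ccc(F)cc43)cc2)nn1`): > 13900 nM (a limit, not a number)

Going by the values given here, compound 1 gives 7320 nM as the only actual number in this assay, so there is no second number against which to rank it. Compound 2 stands at > 13900 nM, which is a limit of the assay.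

Compound 3 (`N#Cc1cccc(-n2cc(-c3ccc(/C=C4\C(=O)Nc5ccc(F)cc54)cc3)nn2)c1`) has not yet been measured. It keeps the core of compound 1 and changes one group: cyano in place of methyl on an aromatic carbon, with cyano in place of methyl on an aromatic carbon, so that 3-methylphenyl becomes 3-cyanophenyl.

Among the compounds with values here, no measured step between compounds differing in one place is available, so the size of this change in this assay cannot be read from the data. The expectation is therefore a modest one: no step beyond the usual scatter, with a slight lean toward weaker inhibition. The expected change is a 1.2-fold higher number from compound 1 to compound 3 (0.09 log units; within the scatter) as estimated here. For compound 3 the expected value is 9000 nM, with an estimated range of 3500 nM to 22000 nM.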

Compound 3, half-maximal inhibitory concentration: > 20000 nM
Compound 3 was reported as a limit (the forecaster's own chance of this, stated with the estimate: 30%); middle value at least 2.2-fold (0.34 log units) from the limit.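

Going by these compounds alone, the swap of methyl for cyano, which turns 3-methylphenyl into 3-cyanophenyl on the shared core, provides the first step in this set between compounds that differ in one place, and in this assay it gives an at least 2.7-fold higher number from compound 1 to compound 3 (0.43 log units; beyond the scatter). Within the data shown here, compound 3 has a limit and not a number, so this step sets a lower bound on the change and does not give its full size: the limit of > 20000 nM in this assay, at which 1 of the 3 values shown sits. At this position, then, the nitrile does not keep the level of inhibition seen with the methyl group of compound 1, and the step lies beyond the usual scatter of repeated measurements, which the earlier compounds alone could not show.

The true value of compound 3 stays unknown, and the data do not say what lies behind the step. Also open, from the compounds shown here alone, is whether a chlorine atom, a methoxy group or an amine at this same place on the ring would read closer to compound 1 or to compound 3, and whether the swap of methyl for cyano would have a like result on a different core.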